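The source may hold more compounds than are shown below. What is called first, only, known or untested is meant among the compounds shown, and "the series" means these compounds.

Measured so far:
compound 1 `NC1CCN(c2nc3c(c(Nc4ccc(C(F)(F)F)cc4)n2)CCN(c2ncccc2C(F)(F)F)CC3)C1` — 3700 nM
compound 2 `CCC(CC)N1CCN(c2nc3c(c(Nc4ccc(C(F)(F)F)cc4)n2)CCN(c2ncccc2C(F)(F)F)CC3)CC1` — 41 nM

Compound 2 gives the lowest of the two numbers in a functional assay on HEK293 cells for antagonist activity at transient receptor potential cation channel subfamily V member 1 (Homo sapiens), read by FLIPR and calcium flux; a lower number here means a stronger inhibitor, a higher number a weaker inhibitor; the nearest is compound 1, reached by a 90-fold lower number from compound 1 to compound 2 (1.96 log units; beyond the scatter). Compound 3 `CN(c1nc2c(c(Nc3ccc(C(F)(F)F)cc3)n1)CCN(c1ncccc1C(F)(F)F)CC2)C1CCCNC1` has not yet been measured in this assay. It differs from compound 2 by methyl(piperidin-3-yl)amino in place of 4-(pentan-3-yl)piperazin-1-yl on an aromatic carbon. Within the data shown here, the only step that bears on this change is the one from compound 1 to compound 2, which was a 90-fold lower number from compound 1 to compound 2 (1.96 log units; beyond the scatter): the group that enters in compound 3 carries one hydrogen-bond donor and a ring with one hetero atom, and thus sits nearer to the 3-aminopyrrolidin-1-yl of compound 1 than to the 4-(pentan-3-yl)piperazin-1-yl of compound 2. A loss of part of that gain is therefore expected, and compound 3 is estimated at 800 nM (range 150 nM to 4000 nM), a step of a 20-fold higher number from compound 2 to compound 3 (1.29 log units; beyond the scatter) expected in this assay.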

Compound 3, half-maximal inhibitory concentration: 3600 nM
For compound 3 the middle estimate is 4.5-fold (0.65 log units) below the measured one; the range from low to high includes it.
By their numbers in this assay, from the lowest: compound 2; then compounds 3 and 1 (each within the scatter of the next).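

In this assay, replacing the 4-(pentan-3-yl)piperazin-1-yl on the aromatic carbon between two ring nitrogen atoms with methyl(piperidin-3-yl)amino gives an 88-fold higher number from compound 2 to compound 3 (1.94 log units; beyond the scatter), so a second, different group at this position also lies far from compound 2. The two groups that replace it cannot be told apart here, with a 1.0-fold lower number from compound 1 to compound 3 (0.01 log units; within the scatter), and among the three compounds only compound 2 stands apart. No measurement at hand accounts for this difference.

The compounds shown leave open whether the low number of compound 2 depends on the pentan-3-yl group or on the piperazine ring, as compound 3 changes the ring, its substituent and the hydrogen-bond donor count together. Unsubstituted piperazin-1-yl and 4-methylpiperazin-1-yl would be the direct comparisons with compound 2.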